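The source may hold more compounds than are shown below. What is called first, only, known or untested is meant among the compounds shown, and "the series" means these compounds.

All four compounds share one core and differ only in the group attached at a carbonyl carbon. In a functional assay on A549 cells (Homo sapiens) for cytotoxicity, read by MTT assay, with a stated time of 48 h (on this read-out higher numbers stand for weaker inhibition and lower numbers for stronger inhibition), compound 1 `C=C1C(=O)O[C@H]2CC3=C[C@H](C/C(C)=C/[C@@H](OC(=O)c4ccc([N+](=O)[O-])cc4)[C@H]12)OC3=O` gives only a limit, > 10000 nM, so its true number is not known. Compound 2 `C=C1C(=O)O[C@H]2CC3=C[C@H](C/C(C)=C/[C@@H](OC(=O)/C=C/c4ccc(C(F)(F)F)cc4)[C@H]12)OC3=O` gives 5900 nM in this assay, and compound 3 `C=C1C(=O)O[C@H]2CC3=C[C@H](C/C(C)=C/[C@@H](OC(=O)C4CCC(F)(F)CC4)[C@H]12)OC3=O` gives 6400 nM. For the measured compounds named here, the one counted step, an at least 1.5-fold lower number from compound 1 to compound 3 (0.19 log units; that floor lies within the scatter), rests on the limit of > 10000 nM in this assay, at which 1 of the 3 values shown sits, and stays within the scatter, so it sets no firm direction. Compound 4 `C=C1C(=O)O[C@H]2CC3=C[C@H](C/C(C)=C/[C@@H](OC(=O)/C=C/c4ccncc4)[C@H]12)OC3=O` carries 2-(pyridin-4-yl)ethenyl in place of 4-nitrophenyl on a carbonyl carbon. Since compound 2, which also bears an ethenyl group, sits at 5900 nM in this assay, a number of the same order is expected for compound 4, an at least 1.4-fold lower number from compound 1 to compound 4 (0.15 log units; that floor lies within the scatter). Compound 4 is therefore estimated at 7000 nM, most likely between 3000 nM and 20000 nM.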

Compound 4, half-maximal inhibitory concentration: 4000 nM
Beside the measured number, compound 4's estimate is 1.8-fold (0.24 log units) above it; low and high end bracket the measured number.
By their numbers in this assay, from the lowest: compounds 4, 2 and 3 (each within the scatter of the next). At a limit, above all of these: compound 1.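

Putting 2-(pyridin-4-yl)ethenyl in place of 4-nitrophenyl gives an at least 2.5-fold lower number from compound 1 to compound 4 (0.39 log units; beyond the scatter) in this assay, the only step shown that clears the scatter, though its size is only a floor set by a limit: the limit of > 10000 nM in this assay, at which 1 of the 4 values shown sits.

Against the other two compounds the change cannot be told apart from noise: pyridin-4-yl for 4-(trifluoromethyl)phenyl gives a 1.5-fold lower number from compound 2 to compound 4 (0.17 log units; within the scatter), and replacing 4,4-difluorocyclohexyl gives a 1.6-fold lower number from compound 3 to compound 4 (0.20 log units; within the scatter).

From the compounds shown here alone, what an amine or a longer chain would give on this carbonyl carbon stays open.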